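Para substituent step on the anilinopyridine diazabicycle series

The compounds below may be only part of what the source reports. "The series", "measured", "known", "first", "only" and "open" are said of these compounds alone.

Measured in an assay on cell membranes for displacement of a labelled ligand from Neuronal acetylcholine receptor; alpha4/beta2 (Rattus norvegicus); on this read-out lower numbers stand for stronger inhibition and higher numbers for weaker inhibition:
compound 1 `c1ccc(Nc2ccc(N3CC4CC(C3)N4)cn2)cc1`: 2.66 nM
compound 2 `O=[N+]([O-])c1ccc(Nc2cncc(N3CC4CC(C3)N4)c2)cc1`: 0.0225 nM
compound 3 `FC(F)(F)c1ccc(Nc2ccc(N3CC4CC(C3)N4)cn2)cc1`: 0.569 nM

Compound 3 gives the second highest of the three numbers in this assay; compound 1 sits above it, and compound 2, which carries a different core and a nitro group, sits far below it. Among the compounds with values here, the one measured step that bears on the next change is a 4.7-fold lower number from compound 1 to compound 3 (0.67 log units; beyond the scatter).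

Compound 4 `Fc1ccc(Nc2ccc(N3CC4CC(C3)N4)cn2)cc1` differs from compound 3 by fluoro in place of trifluoromethyl on an aromatic carbon. Fluoro is neither hydrogen nor trifluoromethyl, so compound 4 is expected to land between compound 1 and compound 3, with a step of a 2.5-fold higher number from compound 3 to compound 4 (0.39 log units; beyond the scatter) that is expected to be small. The estimate for compound 4 in this assay is 1.4 nM, within 0.5 nM to 4 nM.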

Compound 4, inhibition constant: 2.38 nM
For compound 4 the middle estimate is 1.7-fold (0.23 log units) below the measured one; measured number inside the range.
By their numbers in this assay, from the lowest: compound 2; then compound 3; then compounds 4 and 1 (each within the scatter of the next).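

At this position, para to a large group, the step from trifluoromethyl to fluoro is beyond the scatter (a 4.2-fold higher number from compound 3 to compound 4 (0.62 log units; beyond the scatter)). Fluoro in place of hydrogen stays within the scatter (a 1.1-fold lower number from compound 1 to compound 4 (0.05 log units; within the scatter)), so of the two substituents only trifluoromethyl separates from hydrogen. Nothing measured here explains this difference between fluoro and trifluoromethyl. Open, going by these compounds, is whether a nitrile or a methoxy group at this position on the core of compound 1 would track trifluoromethyl or fluoro. Also open, on these data alone, is how much of the low number of compound 2 belongs to its nitro group and how much to its different core.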